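Replacing the 2-hydroxyethyl group of compound 3

The compounds below may be only part of what the source reports. "The series", "measured", "known", "first", "only" and "open" are said of these compounds alone.

In a functional assay on HeLa cells (Homo sapiens) for cytotoxicity, read by MTT assay (a lower number here means a stronger inhibitor, a higher number a weaker inhibitor), three compounds sharing one core have been measured. Compound 3 `CC(C)=CC[C@@H](OCCO)C1=CC(=O)c2c(O)ccc(O)c2C1=O` gives 18600 nM and compound 2 `CC(C)=CC[C@@H](OCC(C)O)C1=CC(=O)c2c(O)ccc(O)c2C1=O` gives 24700 nM, two values within the scatter of each other. Compound 1 `CCCC(CC(=O)O[C@H](CC=C(C)C)C1=CC(=O)c2c(O)ccc(O)c2C1=O)OC(C)=O` gives 51200 nM, which lies beyond the scatter from compound 3. Compound 3 therefore sits with compound 2 at the low end of this small set.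

The next compound, compound 4 `CCC(C)(O)CC(=O)O[C@H](CC=C(C)C)C1=CC(=O)c2c(O)ccc(O)c2C1=O`, alters the group on an oxygen on a saturated carbon: (2-hydroxy-2-methylbutyl)carbonyl in place of 2-hydroxyethyl on an oxygen on a saturated carbon. For the measured compounds named here, only one measured step is available, a 1.3-fold lower number from compound 2 to compound 3 (0.12 log units; within the scatter). It exchanges a methyl for hydrogen and says little about a change of this size. Going by the values given here, the closer guide is compound 1 at 51200 nM, which also carries a carbonyl-bearing group on that oxygen, although no measured compound holds the (2-hydroxy-2-methylbutyl)carbonyl group itself. A higher number than that of compound 3 is therefore expected, modestly beyond the scatter. The estimated step is a 2.2-fold higher number from compound 3 to compound 4 (0.33 log units; beyond the scatter). For compound 4 the estimate is 40000 nM, with an expected range of 18000 nM to 85000 nM.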

Compound 4, half-maximal inhibitory concentration: 25200 nM
Compound 4: the middle estimate sits 1.6-fold (0.20 log units) above what was measured; low and high end bracket the measured number.
By their numbers in this assay, from the lowest: compounds 3, 2 and 4 (each within the scatter of the next); then compound 1.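

In this assay the exchange of 2-hydroxyethyl for (2-hydroxy-2-methylbutyl)carbonyl on an oxygen on a saturated carbon, with 8 heavy atoms entering where 3 leave, gives a 1.4-fold higher number from compound 3 to compound 4 (0.13 log units; within the scatter) and the exchange from 2-hydroxypropyl gives a 1.0-fold higher number from compound 2 to compound 4 (0.01 log units; within the scatter) so that this position accepts the larger carbonyl-bearing group with no shift that can be told from the scatter. The outer part of that group does register, though modestly, with a 2.0-fold lower number from compound 1 to compound 4 (0.31 log units; beyond the scatter) on placing 1-hydroxy-1-methylpropyl where 1-acetoxybutyl stood on a saturated chain carbon bound to a carbonyl carbon, so the carbonyl on this oxygen does not by itself go with the higher number of compound 1. Nothing available here gives a reason for any of these steps.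

The compounds shown leave open whether any group on this oxygen can carry the number beyond the scatter below compound 3, for instance one ending in an amine or a carboxylic acid. They also leave open what a plain ethyl or butyl group without its hydroxyl would do at this position.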